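Swapping the Amide Aryl: Dichlorophenyl to Dimethylphenyl

This account rests on a few compounds, and the source may have more. Where it says the series, first, only, none or still open, it means among the compounds named here.

Measured in a functional assay on CCRF-CEM cells (Homo sapiens) for cytotoxicity; a higher number here means a weaker inhibitor, a lower number a stronger inhibitor:
compound 1 `O=C(/C=C/C(=O)N1C/C(=C\c2ccccc2)C(=O)/C(=C/c2ccccc2)C1)Nc1ccc(Cl)c(Cl)c1` gives 350 nM
compound 2 `Cc1ccc(NC(=O)/C=C/C(=O)N2C/C(=C\c3ccc([N+](=O)[O-])cc3)C(=O)/C(=C/c3ccc([N+](=O)[O-])cc3)C2)cc1` gives 890 nM
compound 3 `O=C(/C=C/C(=O)N1C/C(=C\c2ccc([N+](=O)[O-])cc2)C(=O)/C(=C/c2ccc([N+](=O)[O-])cc2)C1)Nc1ccc(Cl)cc1` gives 810 nM

Compound 1 shows the lowest of the three numbers in this assay; compound 3 sits above it by a margin beyond the scatter, and compound 2 a little further still. Compound 4 `Cc1cccc(C)c1NC(=O)/C=C/C(=O)N1C/C(=C\c2ccccc2)C(=O)/C(=C/c2ccccc2)C1` keeps the core of compound 1 and changes only the aryl group on the amide nitrogen: 2,6-dimethylphenyl in place of 3,4-dichlorophenyl on an amide-type nitrogen. For the measured compounds named here, the only measured step that touches this region is the one between compounds that carry nitro groups on the core, where chloro in place of methyl on an aromatic carbon gave a 1.1-fold lower number from compound 2 to compound 3 (0.04 log units; within the scatter), a shift within the scatter. That step is smaller in scope than the present change and sits on a different core, so it offers limited guidance, but it points to little sensitivity of this assay to substituents on this ring. The expectation is therefore a modest move at most, if any beyond the scatter. The estimated change is a 1.4-fold higher number from compound 1 to compound 4 (0.15 log units; within the scatter). Compound 4 is expected to give 500 nM, with a range from 200 nM to 1300 nM.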

Compound 4, half-maximal inhibitory concentration: 7400 nM
For compound 4 the middle estimate is 15-fold (1.17 log units) below the measured one; measured number above the stated range.
By their numbers in this assay, from the lowest: compound 1; then compounds 3 and 2 (each within the scatter of the next); then compound 4.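

In this assay, the aryl group on the amide-type nitrogen proves to matter a great deal: 2,6-dimethylphenyl in place of 3,4-dichlorophenyl gives a 21-fold higher number from compound 1 to compound 4 (1.33 log units; beyond the scatter) on the shared core. For the compounds shown here, the only earlier step on this ring, a 1.1-fold lower number from compound 2 to compound 3 (0.04 log units; within the scatter) and on a core with nitro groups, showed no such sensitivity, so this position is not indifferent to every change, even though the two groups here match in heavy-atom count, in carrying no hydrogen-bond donors or acceptors, and in having no net charge. No measurement available here accounts for the large step.

This swap alters both the kind of substituent and its placement on the ring, and the compounds shown do not separate the two. A 3,4-dimethylphenyl or a 2,6-dichlorophenyl group on the core of compound 1 would pull them apart, and an unsubstituted phenyl would give a plain reference point.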